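Compound 1 to compound 4: the amine nitrogen substituent

The source may hold more compounds than are shown below. What is called first, only, known or untested is meant among the compounds shown, and "the series" means these compounds.

Within the data shown here, in a functional assay on HeLa cells (Homo sapiens) for antiproliferative activity, read by MTT assay, with a stated time of 48 h (a higher number here means a weaker inhibitor, a lower number a stronger inhibitor), compound 1 (`Cc1ccc(-c2nn(-c3ccccc3)cc2C(Nc2nc3cc(C)c(C)cc3s2)c2c(O)ccc3ccccc23)cc1`) gives 17800 nM as the highest of the three numbers so far. Compound 2 (`O=[N+]([O-])c1ccc(-c2nn(-c3ccccc3)cc2C(Nc2nc3ccccc3s2)c2c(O)ccc3ccccc23)cc1`) at 6810 nM and compound 3 (`Oc1ccc2ccccc2c1C(Nc1nc2ccccc2s1)c1cn(-c2ccccc2)nc1-c1cccc(Cl)c1`) at 6830 nM both lie lower than compound 1 by more than the scatter.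

The change under review leads to compound 4 (`Cc1ccc(-c2nn(-c3ccccc3)cc2C(Nc2nc3ccccc3s2)c2c(O)ccc3ccccc23)cc1`), with 1,3-benzothiazol-2-yl in place of 5,6-dimethyl-1,3-benzothiazol-2-yl on an amine nitrogen. Among the measured compounds shown here, no measured step isolates this change. Compounds 2 and 3 already carry 1,3-benzothiazol-2-yl, but each also differs from compound 1 in a second place, so their lower numbers cannot be credited to this change alone. For the measured compounds named here, the only measured step among them is a 1.0-fold higher number from compound 2 to compound 3 (0.00 log units; within the scatter) with 3-chlorophenyl in place of 4-nitrophenyl on an aromatic carbon. That swap therefore gives no sign that the second place moves the number, though it covers only those two groups.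

A fall towards compounds 2 and 3 is expected, with a wide allowance. The expected step is a 2.1-fold lower number from compound 1 to compound 4 (0.32 log units; beyond the scatter) in this assay as a working estimate. The estimate for compound 4 is 8500 nM with an expected range from 4500 nM to 16000 nM in this assay.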

Compound 4, half-maximal inhibitory concentration: 8050 nM
Estimate against measurement, compound 4: 1.1-fold (0.02 log units) above, within the range that was stated.
By their numbers in this assay, from the lowest: compounds 2, 3 and 4 (each within the scatter of the next); then compound 1.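

Among these compounds, this is the first direct reading of the change on the amine nitrogen: with the rest of the structure held constant, 1,3-benzothiazol-2-yl in place of 5,6-dimethyl-1,3-benzothiazol-2-yl gives a modest step in this assay (a 2.2-fold lower number from compound 1 to compound 4 (0.34 log units; beyond the scatter)). With 1,3-benzothiazol-2-yl held fixed, the swaps on the aromatic carbon stay within the scatter (a 1.2-fold higher number from compound 3 to compound 4 (0.07 log units; within the scatter); a 1.2-fold higher number from compound 2 to compound 4 (0.07 log units; within the scatter)), so among compounds 2, 3 and 4 the choice of 4-methylphenyl, 3-chlorophenyl or 4-nitrophenyl does not separate the numbers, and the gap between compound 1 and these compounds matches the change on the amine nitrogen. No measurement at hand accounts for the step on the amine nitrogen.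

On these data alone, the amine nitrogen change rests on a single matched pair, so it remains open whether the same step would appear with 3-chlorophenyl or 4-nitrophenyl on the aromatic carbon. It also remains open how other groups on the 1,3-benzothiazol-2-yl unit, such as fluoro, methoxy or a single methyl, would compare with the two units shown.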